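A few compounds are considered here, and "the series" means these few. Any claim that something is new, unique, unknown or untested is made for them only; others in the source may bear on it.

Measured so far:
compound 1 `CCOC(=O)/C(=C\c1ccc(OC)c(O)c1)C(=O)c1cc(OC)c(OC)c(OC)c1` — 870 nM
compound 2 `COc1ccc(/C=C(\F)C(=O)c2cc(OC)c(OC)c(OC)c2)cc1O` — 13.7 nM

Within the data shown here, in an ADME assay on K562 cells (Homo sapiens) for cytotoxicity, read by MTT assay, with a stated time of 5 days (on this read-out higher numbers stand for weaker inhibition and lower numbers for stronger inhibition), compound 2 gives the lowest of the two numbers; the one measured step, a 64-fold lower number from compound 1 to compound 2 (1.80 log units; beyond the scatter), concerns a different position. Compound 3 `COc1ccc(/C=C(\F)C(=O)c2cc(OC)c(OC)c(OC)c2)cc1Br` carries bromo in place of hydroxy on an aromatic carbon. Among the measured compounds shown here, no measured step covers this exchange, so the expectation rests on compound 2 alone, whose value 13.7 nM is taken as the anchor. A moderate change in this assay in either direction is expected, with wide uncertainty, so a 2.9-fold higher number from compound 2 to compound 3 (0.47 log units; beyond the scatter) is the estimated step. Compound 3 is estimated at 40 nM, within 8 nM to 200 nM.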

Compound 3, half-maximal inhibitory concentration: 6000 nM
For compound 3 the middle estimate is 150-fold (2.18 log units) below the measured one; the measured number lies above the stated range.
By their numbers in this assay, from the lowest: compound 2; then compound 1; then compound 3.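

In this assay, the aromatic carbon ortho to a methoxy group proves highly sensitive to exchange: bromo in place of hydroxy gives a 440-fold higher number from compound 2 to compound 3 (2.64 log units; beyond the scatter) and so marks this position as far from indifferent, which the earlier step at the double-bonded chain carbon could not show. No measurement at hand accounts for this step.

The compounds shown leave open whether the step follows from losing hydroxy or from bringing in bromo. An amine or a plain hydrogen on this carbon would bear on that question.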